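The compounds below may be only part of what the source reports. "The series", "measured", "known", "first", "only" and "open" are said of these compounds alone.

Of the compounds shown here, three sharing one core have been read in a physicochemical assay for lipophilicity; on this read-out lower numbers stand for lower lipophilicity and higher numbers for higher lipophilicity. Compound 1 `C=C(c1cccc2ccccc12)C1CCC2(CC1)COC(Nc1ccccc1)OO2` gives 5.59, compound 2 `C=C(c1cccc2ccccc12)C1CCC2(CC1)COC(Nc1ccc(F)cc1)OO2` gives 5.75 and compound 3 `C=C(c1cccc2ccccc12)C1CCC2(CC1)COC(Nc1ccc(C)cc1)OO2` gives 6.08. Compound 3 therefore has the highest number of the three, and its gaps to both others lie beyond the scatter.

The next compound, compound 4 `C=C(c1cccc2ccccc12)C1CCC2(CC1)COC(Nc1ccc(OC)cc1)OO2`, has not been measured. It differs from compound 3 in one place, with methoxy in place of methyl on an aromatic carbon, para to a large group (methoxy in place of methyl on an aromatic carbon).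

Among the compounds with values here, no measured step involves methoxy, so the evidence is indirect. The closest guide is the step that introduced the methyl now leaving, a number 0.49 log units higher from compound 1 to compound 3 (beyond the scatter), which is modest. The change from fluoro to methyl gave a number 0.33 log units higher from compound 2 to compound 3 (beyond the scatter), also modest, while fluoro in place of hydrogen gave only a number 0.16 log units higher from compound 1 to compound 2 (within the scatter), within the scatter. Taken together, these steps suggest that compound 3 may give up most of its lead once methyl is gone, leaving compound 4 closer to compound 1 than to compound 3.

The expected step is a number 0.43 log units lower from compound 3 to compound 4 (beyond the scatter), a modest one. For compound 4 the estimated value in this assay is 5.65, with an expected range from 5.35 to 5.95.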

Compound 4, partition coefficient: 5.46
For compound 4 the middle estimate is 0.19 log units above the measured one; low and high end bracket the measured number.
By their numbers in this assay, from the lowest: compounds 4, 1 and 2 (each within the scatter of the next); then compound 3.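

On this aromatic carbon, para to a large group, methoxy in place of methyl gives a number 0.62 log units lower from compound 3 to compound 4 (beyond the scatter) in this assay even though methoxy has more heavy atoms than methyl, so at this position a larger group does not go with a higher number. Methoxy also stays close to the two other groups: replacing hydrogen with it gives a number 0.13 log units lower from compound 1 to compound 4 (within the scatter) and replacing fluoro with it gives a number 0.29 log units lower from compound 2 to compound 4 (within the scatter) and this leaves compound 3, with its methyl, as the only one of the four compounds that stands clear of all the others. No measurement at hand bears on why methyl alone stands apart.

The compounds shown carry only small groups at this one position, so it stays open whether a longer chain such as ethoxy or propyl would sit with methyl or with methoxy, and where an amine or a carboxylic acid on the same carbon would fall. On these data alone, it also stays open whether methoxy in place of methyl would give a similar step at another carbon of this ring or on a different core.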